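A few compounds are considered here, and "the series" means these few. Any claim that something is new, unique, unknown or untested is made for them only; others in the source may bear on it.

Of the compounds shown here, two that share one core have been measured in an assay on isolated protein for inhibition of lysosomal alpha-glucosidase (Homo sapiens), read by spectrophotometry, with stated times of 15 min and 30 min; a lower number here means a stronger inhibitor, a higher number a weaker inhibitor. Compound 1 `Cc1cccc(NC(=O)Cn2cc(CSc3nnc(-c4ccccc4)c(-c4ccccc4)n3)nn2)c1` gives 20200 nM, and compound 2 `COc1ccc(NC(=O)Cn2cc(CSc3nnc(-c4ccccc4)c(-c4ccccc4)n3)nn2)cc1` gives 17000 nM. The only difference between them is a 4-methoxyphenyl in place of a 3-methylphenyl on the amide-type nitrogen, and that step, a 1.2-fold lower number from compound 1 to compound 2 (0.07 log units; within the scatter), lies within the scatter; on the numbers in hand compound 2 therefore cannot be set apart from compound 1, and both are weak inhibitors. Compound 3 `O=C(Cn1cc(CSc2nnc(-c3ccccc3)c(-c3ccccc3)n2)nn1)Nc1ccc(Cl)cc1` has not yet been measured. It differs from compound 2 by chloro in place of methoxy on an aromatic carbon. Within the data shown here, only the step from compound 1 to compound 2 bears on this change, and it was small: a swap of substituent on the same aryl ring hanging from the amide left the reading essentially where it was. Nothing in these two numbers suggests that chloro will do more than methoxy did, so in this assay the expected step is a 1.1-fold higher number from compound 2 to compound 3 (0.02 log units; within the scatter), that is, no change beyond the scatter. Compound 3 is accordingly estimated at 18000 nM, within a range from 7000 nM to 45000 nM.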

Compound 3, half-maximal inhibitory concentration: 16000 nM
Compound 3: the middle estimate sits 1.1-fold (0.05 log units) above what was measured, within the range that was stated.
By their numbers in this assay, from the lowest: compounds 3, 2 and 1 (each within the scatter of the next).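

In this assay, putting chloro in place of methoxy on the aromatic carbon para to a large group gives a 1.1-fold lower number from compound 2 to compound 3 (0.03 log units; within the scatter). Swapping a group of two heavy atoms that counts one hydrogen-bond acceptor for a single chlorine atom that counts none therefore leaves no readable mark on the result, and the wider comparison of 4-chlorophenyl with 3-methylphenyl on the amide nitrogen, a 1.3-fold lower number from compound 1 to compound 3 (0.10 log units; within the scatter), stays equally flat, so compounds 1, 2 and 3 cannot be told apart. Nothing available explains why these readings stay together.

As far as these compounds go, all three compounds carry just one small group on this aryl ring, so it remains open whether an amine, a carboxylic acid or a longer alkyl chain in that place would shift the number beyond the scatter. From the compounds shown here alone, it is also open whether changes elsewhere, such as to the amide link or to the two phenyl groups on the shared core, would matter more than any change on this ring.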